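This account rests on a few compounds, and the source may have more. Where it says the series, first, only, none or still open, it means among the compounds named here.

Compound 1 `O=C(O)CC(O)(CSCCCCCCc1ccc(-c2ccccc2)cc1)C(=O)O` — 38000 nM
Compound 2 `NS(=O)(=O)c1ccc(CCCCCCSCC(O)(CC(=O)O)C(=O)O)cc1` — 500000 nM
Compound 3 `O=C(O)CC(O)(CSCCCCCCc1ccc(O)cc1)C(=O)O` — 420000 nM

In an assay on isolated protein for inhibition of ATP-citrate synthase (Rattus norvegicus) (on this read-out higher numbers stand for weaker inhibition and lower numbers for stronger inhibition), compound 3 gives 420000 nM, the second highest of the three numbers; it sits next to compound 2 and far from compound 1, as the step of an 11-fold higher number from compound 1 to compound 3 (1.04 log units; beyond the scatter) shows. The step of a 1.2-fold lower number from compound 2 to compound 3 (0.08 log units; within the scatter) lies within the scatter, so no order between compound 3 and compound 2 can be read. Compound 4 `O=C(O)CC(O)(CSCCCCCCc1ccc(C(=O)O)cc1)C(=O)O` differs from compound 3 by carboxy in place of hydroxy on an aromatic carbon. Among the measured compounds shown here, two measured steps bear on this change. The step of a 13-fold higher number from compound 1 to compound 2 (1.12 log units; beyond the scatter) and the step of an 11-fold higher number from compound 1 to compound 3 (1.04 log units; beyond the scatter) both show a large rise in this assay when phenyl gives way to a single substituent on the aromatic carbon, while the step of a 1.2-fold lower number from compound 2 to compound 3 (0.08 log units; within the scatter) shows that exchanging one such substituent for another left the number essentially where it was. Compound 4 is therefore expected to stay close to compound 3, with the estimated step of a 1.1-fold lower number from compound 3 to compound 4 (0.02 log units; within the scatter) within the scatter. Compound 4 is estimated at 400000 nM, with a range from 150000 nM to 1000000 nM.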

Compound 4, inhibition constant: 420000 nM
Compound 4: the middle estimate sits 1.1-fold (0.02 log units) below what was measured; low and high end bracket the measured number.
By their numbers in this assay, from the lowest: compound 1; then compounds 3, 4 and 2 (each within the scatter of the next).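

In this assay, carboxy in place of hydroxy on an aromatic carbon para to a large group gives no change at the digits printed from compound 3 to compound 4 (within the scatter), and carboxy in place of sulfamoyl gives a 1.2-fold lower number from compound 2 to compound 4 (0.08 log units; within the scatter), so a third single substituent joins the other two with no order among them. Carboxy in place of phenyl gives an 11-fold higher number from compound 1 to compound 4 (1.04 log units; beyond the scatter), which leaves compound 1 as the only compound shown that stands apart from the others. No independent evidence bears on why the numbers fall this way.

As far as these compounds go, whether the phenyl group itself matters at this position stays open, since a cyclohexyl or butyl group could separate a second ring from plain bulk of carbon. Also open, from the compounds shown here alone, is whether an amine here would stay with compounds 2, 3 and 4, and whether a shorter chain would shift these numbers.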